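Three Close Numbers and a Catechol in Place of Bromine

The compounds below may be only part of what the source reports. "The series", "measured", "known", "first", "only" and "open" are said of these compounds alone.

Of the compounds shown here, three built on one shared core have been tested in an ADME assay on NHDF cells (Homo sapiens) for cytotoxicity, read by MTT assay, with a stated time of 72 h; a higher number here means a weaker inhibitor, a lower number a stronger inhibitor. Compound 1 `COc1cc(/C=C2\CCC/C(=C\c3cccc(OC)c3OC)C2=O)cc(OC)c1` gives 13100 nM. Compound 2 `COc1cccc(/C=C2\CCC/C(=C\c3ccc(O)c(O)c3)C2=O)c1OC` gives 17900 nM. Compound 3 `COc1ccc(/C=C2\CCC/C(=C\c3cccc(Br)c3)C2=O)cc1OC` gives 12400 nM. Although the number of compound 3 is the smallest of the three, its gap to compound 1 and its gap to compound 2 both lie within the usual scatter of repeated measurements, so the three compounds cannot be told apart on these data.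

The next compound, compound 4 `COc1ccc(/C=C2\CCC/C(=C\c3ccc(O)c(O)c3)C2=O)cc1OC`, differs from compound 3 in one place: 3,4-dihydroxyphenyl in place of 3-bromophenyl on a double-bonded chain carbon bound to a double-bonded ring carbon. For the measured compounds named here, no pair of measured compounds shows this exact change, so there is no measured step to lean on. What the data do show is that compound 2, which also carries a 3,4-dihydroxyphenyl group, gives 17900 nM, a number within scatter of the others. Going by the values given here, with every number so far so close, the expectation for compound 4 in this assay is a step of a 1.2-fold higher number from compound 3 to compound 4 (0.08 log units; within the scatter) from compound 3, which means no change beyond the scatter. Compound 4 is therefore expected to give about 15000 nM, with a likely range from 7000 nM to 32000 nM.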

Compound 4, half-maximal inhibitory concentration: 25200 nM
Compound 4: the middle estimate sits 1.7-fold (0.23 log units) below what was measured; low and high end bracket the measured number.
By their numbers in this assay, from the lowest: compounds 3, 1, 2 and 4 (each within the scatter of the next, the first and the last beyond it).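

In this assay, putting 3,4-dihydroxyphenyl in place of 3-bromophenyl on a double-bonded chain carbon bound to a double-bonded ring carbon gives a 2.0-fold higher number from compound 3 to compound 4 (0.31 log units; beyond the scatter) and so reads as a modestly weaker inhibitor. For the compounds shown here, this is the first change in one place, and it shows that the group at this position can move the number beyond the scatter, something the three earlier compounds could not show because they could not be told apart. No measurement at hand bears on why the number moved.

A single step also cannot separate the loss of the bromine from the arrival of the two hydroxyl groups, so a phenyl group carrying just one hydroxyl would be needed to tell how much each contributes. The compounds shown also leave open whether an amine or a carboxylic acid at this place would shift the number further, leave it within the scatter, or move it the other way.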